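From 2-fluorophenyl to furan-2-yl: what to expect

The compounds below may be only part of what the source reports. "The series", "measured", "known", "first", "only" and "open" are said of these compounds alone.

Measured in a functional assay on SGC-7901 cells (Homo sapiens) for antiproliferative activity, read by MTT assay, with a stated time of 48 h; on this read-out lower numbers stand for stronger inhibition and higher numbers for weaker inhibition:
compound 1 `CCOc1ccccc1-c1nnc(SCc2ccc(Cl)nc2)o1`: 10.3 ug/mL
compound 2 `Fc1ccccc1-c1nnc(SCc2ccc(Cl)nc2)o1`: 9.12 ug/mL
compound 3 `COc1ccc(-c2nnc(SCc3ccc(Cl)nc3)o2)cc1OC`: 4.48 ug/mL

The number for compound 2 lies within the scatter of compound 1. Compound 3 gives a lower number than compound 2, and that gap lies beyond the scatter. Compound 4 `Clc1ccc(CSc2nnc(-c3ccco3)o2)cn1` has not yet been measured. It carries furan-2-yl in place of 2-fluorophenyl on an aromatic carbon, and the rest of the molecule stays the same: furan-2-yl in place of 2-fluorophenyl on an aromatic carbon.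

Among the measured compounds shown here, only one measured step bears on this change directly: a 1.1-fold lower number from compound 1 to compound 2 (0.05 log units; within the scatter), with fluoro in place of ethoxy on an aromatic carbon. That step alters a small group on the aromatic part, whereas compound 4 replaces the whole 2-fluorophenyl group, so it is only a weak guide. Compound 3, at 4.48 ug/mL, shows that a lower number is possible with this shared core, so a move in that direction cannot be ruled out. Nothing measured points firmly either way, and no step beyond the scatter is expected: the estimate is a 1.1-fold lower number from compound 2 to compound 4 (0.06 log units; within the scatter).

For compound 4 the expected value in this assay is 8 ug/mL, with an estimated range from 3.5 ug/mL to 18 ug/mL.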

Compound 4, half-maximal inhibitory concentration: 14.3 ug/mL
For compound 4 the middle estimate is 1.8-fold (0.25 log units) below the measured one; the measured number falls inside the stated range.
By their numbers in this assay, from the lowest: compound 3; then compounds 2, 1 and 4 (each within the scatter of the next).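

Compounds 1, 2 and 3 all keep a six-membered aromatic ring of carbon at this position and differ only in the small groups on it, so they say nothing about changing the ring itself. Compound 4 does change it: in this assay, furan-2-yl, a five-membered aromatic ring with 1 hetero atom and 1 hydrogen-bond acceptor, takes the place of 2-fluorophenyl, and the result is a 1.6-fold higher number from compound 2 to compound 4 (0.20 log units; within the scatter). So at this position, on this shared core, the read-out does not separate the two rings, even though the entering group differs from the leaving one in ring size, in its hetero atom and in its acceptor count; nothing available explains this result.

The compounds shown leave open whether this holds beyond aromatic rings, for example for a saturated ring such as cyclohexyl or for a longer chain such as n-butyl at the same place. They also leave open how a phenyl ring carrying an amine or a carboxylic acid would read here, and whether such a group could take the number outside the scatter.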